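Bromo on the phenyl ring of compound 2

This account rests on a few compounds, and the source may have more. Where it says the series, first, only, none or still open, it means among the compounds named here.

Values in a functional assay on ECa-109 cells (Homo sapiens) for antiproliferative activity, read by MTT assay, with a stated time of 72 h; on this read-out higher numbers stand for weaker inhibition and lower numbers for stronger inhibition:
- compound 1 `CCCSc1nc(N/N=C/c2ccc(Br)cc2)c2nnn(Cc3ccccc3)c2n1`: > 64000 nM, a limit and not a number
- compound 2 `CCCSc1nc(N/N=C(\C)c2ccccc2)c2nnn(Cc3ccccc3)c2n1`: 32200 nM

For the measured compounds named here, compound 2 holds the only actual number so far, and compound 1 stays at the limit of > 64000 nM in this assay, at which 1 of the 2 values shown sits.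

Compound 3 `CCCSc1nc(N/N=C(\C)c2ccc(Br)cc2)c2nnn(Cc3ccccc3)c2n1` departs from compound 2 by bromo in place of hydrogen on an aromatic carbon, phenyl to 4-bromophenyl. Going by the values given here, the one measured step, an at least 1.9-fold lower number from compound 1 to compound 2 (0.29 log units; that floor lies within the scatter), bears on this only in part, since it changes more than the bromo. It gives no firm size, so no step beyond the scatter is expected in this assay, with any drift toward weaker inhibition. The expected 1.2-fold higher number from compound 2 to compound 3 (0.07 log units; within the scatter) stays small. Compound 3 is estimated at 38000 nM, within 15000 nM to 64000 nM.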

Compound 3, half-maximal inhibitory concentration: 4670 nM
Estimate against measurement, compound 3: 8.1-fold (0.91 log units) above, and the stated range ends above it.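

In this assay, phenyl to 4-bromophenyl gives a 6.9-fold lower number from compound 2 to compound 3 (0.84 log units; beyond the scatter), so this position responds to bromo, which the earlier pair could not show. With bromo present on both sides, the group of 10 heavy atoms in place of the group of 9 gives an at least 13-fold lower number from compound 1 to compound 3 (1.13 log units; beyond the scatter), so that group also matters apart from the bromo. That step is only a floor, since compound 1 carries a limit and not a number: the limit of > 64000 nM in this assay, at which 1 of the 3 values shown sits.

From the compounds shown here alone, whether chloro, methoxy or an amine at this position would match bromo stays open. Also open, going by these compounds, is whether bromo on another ring carbon would give a similar step.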